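Bromo for hydrogen on the benzyl ring: expected effect

This account rests on a few compounds, and the source may have more. Where it says the series, first, only, none or still open, it means among the compounds named here.

Measured compounds:
compound 1 `c1ccc(COc2nc3ccccc3s2)cc1` — 68.8%
compound 2 `FC(F)(F)c1ccccc1COc1nc2ccccc2s1` — 9.75%

Of the compounds shown here, two have been tested in a functional assay on the whole organism with Mus musculus as the target, with a stated time of 1 h, at a dose of 100 mg/kg by the intraperitoneal route; on this read-out higher numbers stand for more inhibition at the one dose given (going by the name of the read-out) and lower numbers for less inhibition. Among the measured compounds shown here, compound 1 gives the higher of the two numbers in this assay, with compound 2 the only other member, and the step of a number 59.1 percentage points lower from compound 1 to compound 2 (beyond the scatter) is large. The new compound is compound 3 `Brc1ccc(COc2nc3ccccc3s2)cc1`. It differs from compound 1 in one place: bromo in place of hydrogen on an aromatic carbon. The bromo sits para to a large group.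

For the measured compounds named here, only one measured step bears on this change: the one from compound 1 to compound 2, where putting a trifluoromethyl in place of hydrogen on an aromatic carbon cut inhibition sharply. Bromo is a different group from trifluoromethyl, and it sits at a different place on the same ring, so that step is a rough guide at best. Going by the values given here, still, the sole precedent for adding a group to this ring is a large loss, so a drop in inhibition is expected, probably smaller than the measured one. The step is expected to be a number 28.8 percentage points lower from compound 1 to compound 3 (beyond the scatter). Compound 3 is therefore estimated at 40%, within a range from 10% to 70%.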

Compound 3, a percentage reported as inhibition, in the whole organism at one dose (the size of the read-out at that dose, not a potency): 78%
Compound 3: middle estimate off by 38 percentage points, on the low side, and the stated range ends below it.
By their numbers in this assay, from the lowest: compound 2; then compounds 1 and 3 (each within the scatter of the next).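

In this assay, bromo in place of hydrogen on an aromatic carbon, para to a large group, gives a number 9.2 percentage points higher from compound 1 to compound 3 (within the scatter), so at this position the added bromine atom leaves the read-out at the level of the unsubstituted parent. This shows that a group on this ring does not have to cost inhibition: the large loss of a number 59.1 percentage points lower from compound 1 to compound 2 (beyond the scatter) does not extend to every replacement of hydrogen on the ring, and compound 3 is the case that goes against any such rule. No measurement at hand explains why the bromo is accepted here.

It remains open whether the loss in compound 2 belongs to the trifluoromethyl group itself or to its different place on the ring, as only a single group has been shown at each of the two places. Also open, on these data alone, is how other groups at the place of the bromo, such as a chloro, a methoxy, an amine or a carboxylic acid, would behave in this assay.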